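The compounds below may be only part of what the source reports. "The series", "measured", "known", "first", "only" and "open" are said of these compounds alone.

Three closely related compounds have been examined in an ADME assay on the whole organism (Rattus norvegicus, strain Fischer 344) for pharmacokinetics, at a dose of 3 mg/kg by the oral route; on this read-out higher numbers stand for higher exposure at the dose given and lower numbers for lower exposure. Compound 1 `Cc1cc(N2CCC[C@H](COCc3nc(C)no3)C2)c2c(N)c(C(N)=O)sc2n1` gives 451 nM, compound 2 `NC(=O)c1sc2nccc(N3CCC[C@H](COCC(=O)N4CCOCC4)C3)c2c1N` gives 501 nM and compound 3 `NC(=O)c1sc2nccc(N3CCC[C@H](COCCO)C3)c2c1N` gives 326 nM. Compound 3 thus stands within the scatter of both other compounds, and these three numbers show no real separation in this assay.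

The unmeasured compound 4 `CCOCCOC[C@H]1CCCN(c2ccnc3sc(C(N)=O)c(N)c23)C1` differs from compound 3 by one change: ethyl in place of hydrogen on an oxygen on a saturated carbon. In other words, 2-hydroxyethyl becomes 2-ethoxyethyl.

Within the data shown here, only one measured step bears on this change, and it does so indirectly: a 1.5-fold lower number from compound 2 to compound 3 (0.19 log units; within the scatter). That step exchanged (morpholin-4-yl)carbonyl for hydroxymethyl and stayed within the scatter. Among the measured compounds shown here, no measured pair shows ethyl in place of hydrogen on an oxygen on a saturated carbon, so the size of this particular change remains untested. Compound 1 differs from compound 3 in more than one place and offers only a general sense of the range these compounds occupy.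

On this evidence, no shift beyond the scatter is expected, in either direction. The expected change is a 1.1-fold higher number from compound 3 to compound 4 (0.03 log units; within the scatter). Compound 4 is estimated at 350 nM, with an expected range from 130 nM to 900 nM.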

Compound 4, maximal plasma concentration: 2120 nM
Compound 4: middle estimate off by 6.1-fold (0.78 log units), on the low side; measured number outside the range, above it.
By their numbers in this assay, from the lowest: compounds 3, 1 and 2 (each within the scatter of the next); then compound 4.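

Ethyl in place of hydrogen on an oxygen on a saturated carbon gives a 6.5-fold higher number from compound 3 to compound 4 (0.81 log units; beyond the scatter) in this assay. Unlike the earlier step from (morpholin-4-yl)carbonyl to hydroxymethyl, which gave a 1.5-fold lower number from compound 2 to compound 3 (0.19 log units; within the scatter) and stayed within the scatter, this change moves the number beyond the scatter, so this part of the chain can affect the read-out. Ethoxymethyl in place of (morpholin-4-yl)carbonyl on the same saturated chain carbon also gives a 4.2-fold higher number from compound 2 to compound 4 (0.63 log units; beyond the scatter) and so also lies beyond the scatter, and no information here explains why 2-ethoxyethyl gives this result.

These compounds do not show whether the rise is specific to ethyl, since a methyl, a propyl or a longer chain on the same oxygen would be needed to tell whether the number keeps rising, levels off or falls as the group grows. They also leave open whether the ether oxygen must stay, a question that an amine at that place or a plain alkyl chain without that oxygen would address.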